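The source may hold more compounds than are shown below. What is called first, only, known or untested is meant among the compounds shown, and "the series" means these compounds.

Three compounds have values in an ADME assay on MDCKII-LE cells (Canis lupus familiaris) for permeability (a lower number here means that the compound crosses the layer more slowly, a higher number that the compound crosses the layer faster), so far:

- compound 1 `N#Cc1ccc(CN([C@H](CCC(F)(F)F)C(N)=O)S(=O)(=O)c2ccc(Cl)cc2)cc1` reads 19.7 10^-6 cm/s
- compound 2 `N#CCCN([C@H](CCC(F)(F)F)C(N)=O)S(=O)(=O)c1ccc(Cl)cc1` reads 10.2 10^-6 cm/s
- compound 3 `N#CCCCN([C@H](CCC(F)(F)F)C(N)=O)S(=O)(=O)c1ccc(Cl)cc1` reads 27.6 10^-6 cm/s

Compound 3 at 27.6 10^-6 cm/s is not separated from compound 1, with a 1.4-fold higher number from compound 1 to compound 3 (0.15 log units; within the scatter) between them. It does stand clear of compound 2, and that gap is the step of a 2.7-fold higher number from compound 2 to compound 3 (0.43 log units; beyond the scatter) on which the next comparison rests.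

The change to compound 4 `N#CCCCCN([C@H](CCC(F)(F)F)C(N)=O)S(=O)(=O)c1ccc(Cl)cc1` is cyanomethyl in place of cyano on a saturated chain carbon, three bonds along the chain from a sulfonamide nitrogen and in words it is cyanomethyl in place of cyano on a saturated chain carbon, three bonds along the chain from a sulfonamide nitrogen. Read another way, 3-cyanopropyl gives way to 4-cyanobutyl.

For the measured compounds named here, only one measured step is of the same kind, made two bonds along the chain, and that is the modest 2.7-fold higher number from compound 2 to compound 3 (0.43 log units; beyond the scatter) on its own. One step sets no trend, so only a small rise is expected. The expected outcome is a 1.2-fold higher number from compound 3 to compound 4 (0.06 log units; within the scatter) and no move beyond the scatter is anticipated. For compound 4 the estimated value is 32 10^-6 cm/s with an expected range from 16 10^-6 cm/s to 56 10^-6 cm/s in this assay when it is measured.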

Compound 4, apparent permeability: 24 10^-6 cm/s
Compound 4: the middle estimate sits 1.3-fold (0.12 log units) above what was measured; the measured number falls inside the stated range.
By their numbers in this assay, from the lowest: compounds 2, 1, 4 and 3 (each within the scatter of the next, the first and the last beyond it).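

In this assay, going from 3-cyanopropyl to 4-cyanobutyl gives a 1.2-fold lower number from compound 3 to compound 4 (0.06 log units; within the scatter), so the gain seen on the previous lengthening of the chain does not carry on at this position. The longer chain nevertheless keeps its separation from the shortest one, with a 2.4-fold higher number from compound 2 to compound 4 (0.37 log units; beyond the scatter), while a 1.2-fold higher number from compound 1 to compound 4 (0.09 log units; within the scatter) leaves the chain of compound 4 and the 4-cyanophenyl-bearing group of compound 1 unseparated. Nothing available explains why the gain stops at this chain length.

The compounds shown leave open whether a still longer chain would stay level with compound 3 and compound 4 or move away from them. They also do not tell how an amine or a carboxylic acid in place of the nitrile would read on the same chain.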